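The source may hold more compounds than are shown below. What is called first, only, known or untested is meant among the compounds shown, and "the series" means these compounds.

Measured compounds:
- compound 1, `CCc1cc(Br)ccc1C/N=c1\c(O)c(O)\c1=N/C(C)(C)C`: 270 nM
- compound 2, `N#Cc1ccc(CNc2c(N)c(=O)c2=O)cc1`: > 30000 nM

Compound 1 carries the structure `CCc1cc(Br)ccc1C/N=c1\c(O)c(O)\c1=N/C(C)(C)C` and gives a number in a functional assay for inhibition, with Rattus norvegicus as the target; a lower number here means a stronger inhibitor, a higher number a weaker inhibitor. In this assay compound 1 gives 270 nM. Compound 2, with the structure `N#Cc1ccc(CNc2c(N)c(=O)c2=O)cc1`, gives no number in this assay. In this assay compound 2 stands at > 30000 nM, which is a limit of the assay and not a measured value. Of the two measurements shown, one sits at the limit of > 30000 nM in this assay, at which 1 of the 2 values shown sits, and that one belongs to compound 2.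

Compound 3, `CN(C)c1c(NCc2ccc(C#N)cc2)c(=O)c1=O`, has not yet been measured in this assay. It differs from compound 2 in one place: dimethylamino in place of amino on an aromatic carbon. The change is small and sits on the same small aromatic core, next to the ring atom that bears a large group. Among the measured compounds shown here, with compound 2 already at a limit, no measured step exists on which to scale an expectation, and the step from compound 2 to compound 3 is expected to stay within the scatter, so compound 3 is expected to remain at or beyond the limit a number no higher from compound 2 to compound 3 (the limit leaves the size open). The estimate for compound 3 in this assay is 30000 nM, with a range from 8000 nM to 100000 nM.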

Compound 3, half-maximal inhibitory concentration: > 30000 nM
Compound 3 ended at the assay's limit; the forecaster's own chance of this, stated with the estimate: 70%; the middle value lies on the limit itself.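

Compound 2 and compound 3 both end at a limit of this assay and not at a measured number, so no step can be read between them: the limit of > 30000 nM in this assay, at which 2 of the 3 values shown sit.

The compounds shown leave open how far past that limit each one lies, and whether dimethylamino in place of amino on an aromatic carbon changes the number at all.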